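Adding One Fluoro Group to Compound 2

This account rests on a few compounds, and the source may have more. Where it says the series, first, only, none or still open, it means among the compounds named here.

Compound 1 `COc1ccc(-c2nc3cnccc3n2-c2cc(OC)c(OC)c(OC)c2)cc1O`: > 20000 nM
Compound 2 `COc1ccc(-c2cc3c(cn2)[nH]c(=O)n3-c2cc(OC)c(OC)c(OC)c2)cc1`: 1210 nM

Both compounds were tested in a functional assay on HeLa cells (Homo sapiens) for antiproliferative activity, read by MTT assay, with a stated time of 48 h; on this read-out lower numbers stand for stronger inhibition and higher numbers for weaker inhibition. In this assay, compound 1 gives > 20000 nM, which is a limit and not a number. Within the data shown here, compound 2, at 1210 nM, therefore holds the only actual number so far. Compound 3 `COc1ccc(-c2cc3c(cn2)[nH]c(=O)n3-c2cc(OC)c(OC)c(OC)c2)cc1F` differs from compound 2 in one place: fluoro in place of hydrogen on an aromatic carbon. This puts fluoro in place of hydrogen on an aromatic carbon, ortho to a methoxy group. Among the measured compounds shown here, no measured pair shows what this change does, so no shift beyond the usual scatter is expected. The expected size is a 1.3-fold lower number from compound 2 to compound 3 (0.13 log units; within the scatter). For compound 3 the estimate is 900 nM, with an expected range from 300 nM to 3000 nM.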

Compound 3, half-maximal inhibitory concentration: 2210 nM
Compound 3: the middle estimate sits 2.5-fold (0.39 log units) below what was measured, and the stated range covers the measured number.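

On the ring carrying the methoxy group, going from 4-methoxyphenyl to 3-fluoro-4-methoxyphenyl gives a 1.8-fold higher number from compound 2 to compound 3 (0.26 log units; within the scatter) in this assay, so this place accepts a fluoro group with no shift that can be told from the scatter. It is the first measured step at this place, and the only step among the compounds shown. Nothing measured here accounts for the result.

One fluoro group says little about the place as a whole. From the compounds shown here alone, whether an amine or a carboxylic acid here would leave the number where it stands remains open.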